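The compounds below may be only part of what the source reports. "The series", "measured", "known", "first", "only" and "open" are said of these compounds alone.

Compound 1 `Cc1ccccc1S(=O)(=O)NC(C1=CC(=O)c2c(O)ccc(O)c2C1=O)C(C)C`: 190 nM
Compound 2 `CC(C)C(NS(=O)(=O)c1ccc(F)cc1)C1=CC(=O)c2c(O)ccc(O)c2C1=O`: "not determined" (no result reported)
Compound 3 `Cc1ccccc1S(=O)(=O)NC(C)C1=CC(=O)c2c(O)ccc(O)c2C1=O`: 70 nM

In a functional assay on HL-60 cells (Homo sapiens) for cytotoxicity, read by MTT assay (on this read-out lower numbers stand for stronger inhibition and higher numbers for weaker inhibition), compound 3 holds the lower of the two numbers, 70 nM, and compound 2 has no number to compare. The next compound, compound 4 `CC(NS(=O)(=O)c1ccc(Cl)cc1)C1=CC(=O)c2c(O)ccc(O)c2C1=O`, puts 4-chlorophenyl in place of 2-methylphenyl on a sulfonyl sulfur. Within the data shown here, the only measured step, a 2.7-fold lower number from compound 1 to compound 3 (0.43 log units; beyond the scatter), was a modest one made on a saturated chain carbon, not on the sulfonyl sulfur. Among the measured compounds shown here, no measured step therefore bears directly on this change, and no shift beyond the scatter can be predicted in this assay in either direction. The expected step is a 1.1-fold higher number from compound 3 to compound 4 (0.06 log units; within the scatter). For compound 4 the estimated value is 80 nM, with an expected range of 25 nM to 250 nM.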

Compound 4, half-maximal inhibitory concentration: 250 nM
The estimate for compound 4 lay 3.1-fold (0.49 log units) below the measured number, within the range that was stated.
By their numbers in this assay, from the lowest: compound 3; then compounds 1 and 4 (each within the scatter of the next).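

In this assay the swap of 2-methylphenyl for 4-chlorophenyl on the sulfonyl sulfur gives a 3.6-fold higher number from compound 3 to compound 4 (0.55 log units; beyond the scatter) and so shows that the number responds to the group at this position, which the earlier step on the saturated chain carbon could not show. Both groups count the same heavy atoms and one aromatic ring, so those counts do not separate them. Nothing available explains the shift. Still open, on these data alone, is how an unsubstituted phenyl, a 4-methylphenyl or a 2-chlorophenyl would compare on this sulfur, which would help separate the part played by the chlorine from that of the methyl.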